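Swapping the ether linker for a direct aryl amide

A few compounds are considered here, and "the series" means these few. Any claim that something is new, unique, unknown or untested is made for them only; others in the source may bear on it.

Three compounds share one core, a thiosemicarbazide joined to a biphenylmethyl group, and differ only in the ring that hangs from the carbonyl through an oxygen and a saturated carbon. In an assay on isolated protein for inhibition of A disintegrin and metalloproteinase with thrombospondin motifs 5 (Homo sapiens), read by spectrophotometry, with stated times of 10 min and 3 h (a higher number here means a weaker inhibitor, a lower number a stronger inhibitor), compound 1, with the structure `O=C(COc1ccc(Cl)cc1)NNC(=S)NCc1ccc(-c2ccccc2)cc1`, gives 1200 nM. Compound 2, `O=C(COc1ccccc1Cl)NNC(=S)NCc1ccc(-c2ccccc2)cc1`, gives 1900 nM in this assay, and compound 3, `O=C(COc1ccc(Cl)cc1Cl)NNC(=S)NCc1ccc(-c2ccccc2)cc1`, gives 1200 nM. The measured steps are small: a 1.6-fold higher number from compound 1 to compound 2 (0.20 log units; within the scatter), no change at the digits printed from compound 1 to compound 3 (within the scatter) and a 1.6-fold lower number from compound 2 to compound 3 (0.20 log units; within the scatter). Compound 1 thus sits level with compound 3 at the lowest of the three numbers, with compound 2 no further away than the scatter allows.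

Compound 4, `O=C(NNC(=S)NCc1ccc(-c2ccccc2)cc1)c1ccc(Cl)cc1`, changes something else: 4-chlorophenyl in place of (4-chlorophenoxy)methyl on a carbonyl carbon. Going by the values given here, none of the measured steps touches this part of the molecule, since each of them only moves or adds a chloro on the outer ring while the oxygen and saturated carbon stay in place. Among the compounds with values here, with no step bearing directly on the change, the expectation for compound 4 in this assay is a number within the scatter of compound 1, estimated as 1500 nM with a range from 500 nM to 5000 nM. The expected step is a 1.3-fold higher number from compound 1 to compound 4 (0.10 log units; within the scatter).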

Compound 4, half-maximal inhibitory concentration: 700 nM
Beside the measured number, compound 4's estimate is 2.1-fold (0.33 log units) above it; the measured number falls inside the stated range.
By their numbers in this assay, from the lowest: compounds 4, 1, 3 and 2 (each within the scatter of the next, the first and the last beyond it).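

Until now only a chloro had moved or been added on the outer ring, whereas compound 4 removes the oxygen and the saturated carbon that joined that ring to the carbonyl, and the number in this assay stays within the scatter of both closest comparisons (a 1.7-fold lower number from compound 1 to compound 4 (0.23 log units; within the scatter); a 1.7-fold lower number from compound 3 to compound 4 (0.23 log units; within the scatter)). At this place on a carbonyl carbon, then, 4-chlorophenyl can stand in place of (4-chlorophenoxy)methyl with no loss of inhibition beyond the scatter, so among these compounds the oxygen and saturated carbon are not needed to hold this level. Only the comparison with the (2-chlorophenoxy)methyl group of compound 2 clears the scatter, and then only modestly (a 2.7-fold lower number from compound 2 to compound 4 (0.43 log units; beyond the scatter)), a step that removes the link and also changes where the chloro sits on the ring.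

Nothing among the available data explains why the directly attached ring holds this level. Still open, as far as these compounds go, is whether a longer chain such as 2-(4-chlorophenyl)ethyl on the carbonyl carbon, or an amine or a carboxylic acid in place of the chloro on the ring, would keep it.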